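This account rests on a few compounds, and the source may have more. Where it says the series, first, only, none or still open, it means among the compounds named here.

Measured in a functional assay on HepG2 cells (Homo sapiens) for inhibition, read by sulforhodamine B assay, with a stated time of 72 h; a higher number here means a weaker inhibitor, a lower number a stronger inhibitor:
- Compound 1 `C[C@H](Nc1nc(N)nc2[nH]cnc12)c1nn(-c2cccnc2)c2cc(F)ccc12`: > 40000 nM (a limit of the assay, not a number)
- Compound 2 `C[C@H](Nc1ncnc2[nH]cnc12)c1nn(-c2ccc(C#N)cc2)c2cc(F)ccc12`: 15100 nM
- Compound 3 `CC[C@H](Nc1ncnc2[nH]cnc12)c1nn(-c2cccnc2)c2cc(F)ccc12`: 33900 nM

Of the two true numbers, compound 2 at 15100 nM holds the lower, and the gap to compound 3 at 33900 nM lies beyond the scatter. Compound 4 `C[C@H](Nc1ncnc2[nH]cnc12)c1nn(-c2cc(F)cc(F)c2)c2cc(F)ccc12` carries 3,5-difluorophenyl in place of 4-cyanophenyl on an aromatic nitrogen. Among the measured compounds shown here, no measured pair isolates this exchange, so in this assay only a modest move toward a higher number is expected, possibly none beyond the scatter. The expected step is a 1.3-fold higher number from compound 2 to compound 4 (0.10 log units; within the scatter). For compound 4 the estimated value is 19000 nM. The expected range for compound 4 runs from 8000 nM to 40000 nM.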

Compound 4, half-maximal inhibitory concentration: 22100 nM
Compound 4: the middle estimate sits 1.2-fold (0.07 log units) below what was measured; the measured number falls inside the stated range.
By their numbers in this assay, from the lowest: compounds 2, 4 and 3 (each within the scatter of the next, the first and the last beyond it). At a limit, above all of these: compound 1.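

Among the compounds shown here, this pair is the first in the set to differ in one place only, and in this assay it gives a 1.5-fold higher number from compound 2 to compound 4 (0.17 log units; within the scatter). At this aromatic nitrogen, then, 3,5-difluorophenyl and 4-cyanophenyl cannot be told apart, so the nitrile is not required for the number seen with compound 2. Both numbers remain in the same high range as the ceiling reached in this set: the limit of > 40000 nM in this assay, at which 1 of the 4 values shown sits.

The compounds shown leave open whether an amine or a carboxylic acid on the phenyl ring would move the number beyond the scatter. From the compounds shown here alone, whether a morpholine in place of the phenyl ring would do so also remains open.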